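Methyl Step Repeated on a Nitro-Bearing Core

The source may report more compounds than this note shows. Statements on the series, on what has been measured and on what is new or still open speak of the compounds shown alone.

Compound 1, `Cc1ccc(NC(=O)/C=C/C(=O)N2C/C(=C\c3ccccc3)C(=O)/C(=C/c3ccccc3)C2)cc1`, gives 1100 nM in a functional assay on CCRF-CEM cells (Homo sapiens) for cytotoxicity; a higher number here means a weaker inhibitor, a lower number a stronger inhibitor.
Compound 2, `O=C(/C=C/C(=O)N1C/C(=C\c2ccccc2)C(=O)/C(=C/c2ccccc2)C1)Nc1ccccc1`, gives 1100 nM in this assay.
Compound 3, `O=C(/C=C/C(=O)N1C/C(=C\c2ccc([N+](=O)[O-])cc2)C(=O)/C(=C/c2ccc([N+](=O)[O-])cc2)C1)Nc1ccccc1`, gives 370 nM in this assay.

Compound 3 stands lowest of the three; its nearest neighbour is compound 1 and its furthest is compound 2, and both gaps lie beyond the scatter. Compound 2 and compound 1 differ by one change, (methyl in place of hydrogen on an aromatic carbon), and the step of no change at the digits printed from compound 2 to compound 1 (within the scatter) is flat. The difference between the core of compound 2 and the core of compound 3 is not broken down here.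

Compound 4, `Cc1ccc(NC(=O)/C=C/C(=O)N2C/C(=C\c3ccc([N+](=O)[O-])cc3)C(=O)/C(=C/c3ccc([N+](=O)[O-])cc3)C2)cc1`, has not yet been measured. It differs from compound 3 by methyl in place of hydrogen on an aromatic carbon, which is the same change as that from compound 2 to compound 1, set on the same place. Since that earlier step was flat, compound 4 is estimated to sit close to compound 3, with the expected step of no change at the digits printed from compound 3 to compound 4 (within the scatter) resting on no change at the digits printed from compound 2 to compound 1 (within the scatter). In this assay compound 4 is expected to give about 370 nM, most likely between 180 nM and 760 nM.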

Compound 4, half-maximal inhibitory concentration: 890 nM
Estimate against measurement, compound 4: 2.4-fold (0.38 log units) below; the measured number lies above the stated range.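

In this assay, methyl in place of hydrogen on an aromatic carbon gave a 2.4-fold higher number from compound 3 to compound 4 (0.38 log units; beyond the scatter), a modest step beyond the scatter, whereas the same change on the other core gave no change at the digits printed from compound 2 to compound 1 (within the scatter) and stayed within it. Set side by side, however, the two steps cannot be told apart: the same change on two cores in this assay, no change at the digits printed (within the scatter) from compound 2 to compound 1 and a 2.4-fold higher number (0.38 log units; beyond the scatter) from compound 3 to compound 4, 2.4-fold (0.38 log units) apart, within the scatter of two such steps

Among the compounds shown here, the pair therefore gives no firm sign that the core alters what this methyl does, but with only two cores it does not show that the change carries over unaltered either, and a real difference of this size would go unresolved.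

The compounds shown leave open whether an ethyl group, a methoxy group or a chlorine atom in the place of this methyl would move the number in the same way on both cores. They also leave open how the step would read on a core bearing a nitrile or an amine in the place of the nitro groups.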